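The source may report more compounds than this note shows. Statements on the series, on what has been measured and on what is new or still open speak of the compounds shown alone.

Of the compounds shown here, three have been measured in a functional assay on cells (Breast cancer cell line, Homo sapiens) for inhibition; a higher number here means a weaker inhibitor of growth, a lower number a stronger inhibitor of growth. Compound 1 `Cc1ccc(/C=C2\CN(C)CC3=C2N=C(S)NC3c2ccc(C)cc2)cc1` gives 39400 nM. Compound 2 `COc1ccc(/C=C2\CN(C)CC3=C2N=C(S)NC3c2ccc(OC)cc2)cc1` gives 11100 nM. Compound 3 `CN1C/C(=C\c2cccs2)C2=NN(C)C(c3cccs3)C2C1`, built on a different core from the other two, gives 86000 nM, the highest number of the three, which means the weakest growth inhibition seen so far. The number for compound 1 is lower than that of compound 3 by a margin beyond the usual scatter, and the number for compound 2 is lower still, also beyond the scatter, so compound 3 stands clearly at the weak end of this small set.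

The next compound, compound 4 `CN1C/C(=C\c2cccs2)C2=NN(c3ccccc3)C(c3cccs3)C2C1`, differs from compound 3 in one place: phenyl in place of methyl on an amine nitrogen in a ring. For the measured compounds named here, no pair of measured compounds in this set differs by a change of this kind, so there is no measured step to lean on; the only guide is the value of compound 3 itself.

With nothing to suggest a large shift, the step of a 1.4-fold lower number from compound 3 to compound 4 (0.16 log units; within the scatter) is expected to be small, with at most a slight move toward stronger inhibition. Compound 4 is therefore estimated at 60000 nM, within a range from 15000 nM to 200000 nM.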

Compound 4, concentration for 50% growth inhibition: 23600 nM
The estimate for compound 4 lay 2.5-fold (0.41 log units) above the measured number, within the range that was stated.
By their numbers in this assay, from the lowest: compound 2; then compounds 4 and 1 (each within the scatter of the next); then compound 3.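

In this assay, for the compounds shown here, a 3.6-fold lower number from compound 3 to compound 4 (0.56 log units; beyond the scatter), a modest step but one beyond the scatter, and the first measured step in this set between two compounds that differ in one place. It shows that on this amine nitrogen in a ring, next to the ring atom that bears a thiophen-2-yl group, the small methyl can give way to the much larger phenyl with a gain in growth inhibition rather than a loss. Nothing measured here explains this gain.

Methyl and phenyl are the only groups shown on this nitrogen, and they come from a single pair on a single core, so it stays open whether the gain depends on an aromatic ring or would also come with a non-aromatic group such as cyclohexyl or a longer chain such as butyl. Also open, as far as these compounds go, is how a benzyl group, with a carbon link between the nitrogen and the ring, or a pyridyl ring, which has a nitrogen in the ring, would compare with phenyl at this position.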